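Methyl Ester to Carboxylic Acid on a Shared Core

A few compounds are considered here, and "the series" means these few. Any claim that something is new, unique, unknown or untested is made for them only; others in the source may bear on it.

Among the measured compounds shown here, compound 2 `COC(=O)c1cccc(-c2cnc(C(O)CCCCCCc3ccccc3)o2)n1` stands lowest of the two numbers measured so far: in an assay (Rattus norvegicus) for inhibition of Fatty-acid amide hydrolase 1 (Homo sapiens) (a higher number here means a weaker inhibitor, a lower number a stronger inhibitor), compound 2 gives 2300 nM, whereas compound 1 `NC(=O)c1cnc(C(O)CCCCCCc2ccccc2)o1` gives 25000 nM, a gap beyond the usual scatter. Compound 3 `O=C(O)c1cccc(-c2cnc(C(O)CCCCCCc3ccccc3)o2)n1` differs from compound 2 by a single change, hydrogen in place of methyl on an oxygen next to a carbonyl group. For the measured compounds named here, no measured pair shows this change, so its size can only be expected; a modest weakening is anticipated, a 3.0-fold higher number from compound 2 to compound 3 (0.48 log units; beyond the scatter). Compound 3 is therefore estimated at 7000 nM, with a range from 2000 nM to 25000 nM.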

Compound 3, inhibition constant: > 10000 nM
Compound 3: only a limit was reported; the forecaster's own chance of this, stated with the estimate: 10%; middle value at least 1.4-fold (0.15 log units) away from the limit.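

In this assay, among the compounds shown here, the change from methoxycarbonyl to carboxy gives an at least 4.3-fold higher number from compound 2 to compound 3 (0.63 log units; beyond the scatter) on the shared core, the first reading of this change, and the methyl ester holds the lower number. For compound 3 the reported > 10000 nM is a limit of the assay and not a number. The step from compound 1 to compound 3 cannot be read. From the compounds shown here alone, how far the weakening extends remains open, as does whether an amide or a hydroxymethyl group in place of the methoxycarbonyl would match the methyl ester.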